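This account rests on a few compounds, and the source may have more. Where it says the series, first, only, none or still open, it means among the compounds named here.

Measured compounds:
Compound 1 `O=C(O)Cc1sc(C(c2ccc(F)cc2)c2ccc(F)cc2)nc1-c1ccnc(Cl)c1` — 80%
Compound 2 `O=C(O)Cc1sc(C(c2ccccc2)c2ccccc2)nc1-c1ccc(F)c(F)c1` — 80%

The study examines two measured compounds that share a core and are read in an in vitro functional assay on HEK285-7 cells for antagonist activity at prostaglandin D2 receptor 2 (Homo sapiens), read by BRET and beta-arrestin recruitment; a higher number here means a larger maximal response, a lower number a smaller maximal response. Compound 1 `O=C(O)Cc1sc(C(c2ccc(F)cc2)c2ccc(F)cc2)nc1-c1ccnc(Cl)c1` gives 80% in this assay. Compound 2 `O=C(O)Cc1sc(C(c2ccccc2)c2ccccc2)nc1-c1ccc(F)c(F)c1` gives 80% in this assay. Compound 1 therefore stands level with compound 2 at the digits printed, and the two values fall within the usual scatter of each other, so no order between them can be drawn.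

The unmeasured compound 3 `N#Cc1cc(-c2nc(C(c3ccc(F)cc3)c3ccc(F)cc3)sc2CC(=O)O)ccc1F` arises from compound 1 by a single change on the shared core: 3-cyano-4-fluorophenyl in place of 2-chloropyridin-4-yl on an aromatic carbon. Among the compounds with values here, both compounds measured so far reach the same maximal response, and no step between measured compounds is available to show how a change at this position moves this assay. The expectation is therefore a step of no change at the digits printed from compound 1 to compound 3 (within the scatter) from compound 1 to compound 3, that is, none beyond the scatter. Compound 3 is expected to give about 80% in this assay, within a range from 65% to 95%.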

Compound 3, largest response reached (reported as efficacy), in percent of the reference or control that the assay uses: 80%
For compound 3 middle estimate and measured number coincide at the digits printed; the range from low to high includes it.
By their numbers in this assay, from the lowest: compounds 1, 2 and 3 (each within the scatter of the next).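

In this assay, putting 3-cyano-4-fluorophenyl in place of 2-chloropyridin-4-yl, on the aromatic carbon next to the ring nitrogen of the shared core, gives no change at the digits printed from compound 1 to compound 3 (within the scatter). Within the data shown here, this is the first step read at this position, and it shows that a six-membered aromatic ring of carbon only, carrying a nitrile and a fluorine, can stand where a chlorinated ring with one hetero atom stood without a difference beyond the scatter in the largest response reached. Nothing in the information available accounts for this result, so it remains an observation about these two groups alone.

The compounds shown leave open whether the same level would hold with a group of another kind at this position, such as an amine or a longer alkyl chain, since only substituted six-membered aromatic rings stand there. Going by these compounds, because the ring atoms and all the substituents on that ring are exchanged together in this single step, it also remains open how the chlorine, the ring nitrogen, the nitrile and the fluorine would each read on their own.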